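The compounds below may be only part of what the source reports. "The series", "measured", "known", "first", "only" and "open" are said of these compounds alone.

Measured compounds:

Compound 1, `COc1ccc(-c2c(-c3cc(OC)c(OC)c(OC)c3)ssc2=O)cc1[N+](=O)[O-]`. In a functional assay on SGC-7901 cells (Homo sapiens) for antiproliferative activity, read by MTT assay, with a stated time of 72 h (a lower number here means a stronger inhibitor, a higher number a weaker inhibitor), compound 1 gives > 100000 nM, which is a limit of the assay and not a number.

Compound 2, `COc1ccc(-c2c(-c3cc(OC)c(OC)c(OC)c3)ssc2=O)cc1N`. In this assay compound 2 gives > 100000 nM, again a limit of the assay.

Compound 3, `CO/N=c1/ssc(-c2cc(OC)c(OC)c(OC)c2)c1-c1ccc(OC)c([N+](=O)[O-])c1`. In this assay compound 3 gives > 100000 nM, a limit as well.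

Compound 4, `CO/N=c1/ssc(-c2cc(OC)c(OC)c(OC)c2)c1-c1ccc(OC)c(N)c1`, is not yet measured. It is reached from compound 3 by the same change that turns compound 1 into compound 2. That change, (amino in place of nitro on an aromatic carbon), gave a step that the two limits leave unreadable from compound 1 to compound 2. The change from compound 3 to compound 4 is amino in place of nitro on an aromatic carbon, made at a place described in the same words. The difference between the two cores is not broken down here.

For compound 4 the expected step is a step that the limit leaves unreadable from compound 3 to compound 4, and this rests on the limit of > 100000 nM in this assay, at which 3 of the 3 values shown sit, together with the unreadable a step that the two limits leave unreadable from compound 1 to compound 2. Compound 4 is therefore expected at 150000 nM, with an estimated range from 40000 nM to 600000 nM, most likely reported as a limit once more.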

Compound 4, half-maximal inhibitory concentration: 1960 nM
Beside the measured number, compound 4's estimate is 77-fold (1.88 log units) above it; measured number below the stated range.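

In this assay, amino in place of nitro on an aromatic carbon gives an at least 51-fold lower number from compound 3 to compound 4 (1.70 log units; beyond the scatter), so on the core of compound 3 the change leads from a limit of the assay to a readable value. On the core of compound 1 the step cannot be read, as both of its compounds stand at a limit, and compound 2, which carries the same amino group, gives > 100000 nM, a limit and not a number. The change is therefore shown to pay off on one core only, and carrying it from one core to the other is not shown.

Open, as far as these compounds go, is whether the amino group itself is needed on the core of compound 3, or whether a hydroxyl, acetamide or dimethylamino group at the same place would also give a readable value.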